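The compounds below may be only part of what the source reports. "The series", "measured", "known", "first", "only" and "open" are said of these compounds alone.

Working notes on the pyrazoline series.

Three compounds have numbers in a functional assay on WM 266-4 cells (Homo sapiens) for antiproliferative activity, read by MTT assay, with a stated time of 24 h; a lower number here means a stronger inhibitor of growth, a higher number a weaker inhibitor of growth. Compound 1 `COc1ccc(C2=NN(C(=O)c3ccc(C)nc3)C(c3ccc(OCc4ccccc4)cc3)C2)cc1` gives 7950 nM. Compound 2 `O=C(c1cncc(Br)c1)N1N=C(c2ccc(Cl)cc2)CC1c1ccc(OCc2ccccc2)cc1` gives 8130 nM. Compound 3 `Cc1ccc(C(=O)N2N=C(c3ccc(Cl)cc3)CC2c2ccc(OCc3ccccc3)cc2)c(Cl)n1` gives 11400 nM, the highest of the three numbers, though its gaps to compound 2 and to compound 1 are both within the scatter, so the three stand together. For the measured compounds named here, the one single-place step measured so far, a 1.4-fold higher number from compound 2 to compound 3 (0.15 log units; within the scatter), exchanges the whole acyl aryl ring and leaves the number where it was.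

Compound 4 `Cc1ccc(C(=O)N2N=C(c3ccc(Cl)cc3)CC2c2ccc(OCc3ccccc3)cc2)cn1` differs from compound 3 in one place: hydrogen in place of chloro on an aromatic carbon, the chloro sitting next to the ring nitrogen on the acyl ring. Going by the values given here, no measured pair isolates this chloro. Among the compounds with values here, compound 1 shares the acyl group of compound 4 but carries a different ring on the pyrazoline, so it offers no clean step; its number and that of compound 3 sit within the scatter of each other. Given that the larger acyl exchange from compound 2 to compound 3 moved nothing beyond the scatter, the expectation for removing one chloro is a step of no size beyond the scatter, a 1.3-fold lower number from compound 3 to compound 4 (0.10 log units; within the scatter). Compound 4 is therefore estimated at 9000 nM, with a range from 4000 nM to 20000 nM.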

Compound 4, concentration for 50% growth inhibition: 9200 nM
The estimate for compound 4 lay 1.0-fold (0.01 log units) below the measured number, within the range that was stated.
By their numbers in this assay, from the lowest: compounds 1, 2, 4 and 3 (each within the scatter of the next).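

In this assay the step of a 1.2-fold lower number from compound 3 to compound 4 (0.09 log units; within the scatter) isolates the chloro on the aromatic carbon next to the ring nitrogen, and this position holds chloro or hydrogen with no change beyond the scatter. The same holds for the step of a 1.1-fold higher number from compound 2 to compound 4 (0.05 log units; within the scatter) with 6-methylpyridin-3-yl in place of 5-bromopyridin-3-yl on the carbonyl carbon, which adds a second acyl exchange that stays within the scatter. The step of a 1.2-fold higher number from compound 1 to compound 4 (0.06 log units; within the scatter) with chloro in place of methoxy on an aromatic carbon is the first single-place reading outside the acyl group, and it too stays within the scatter, so none of the steps among these four compounds goes beyond it.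

Still open, from the compounds shown here alone, is whether this position answers to anything other than chloro or hydrogen, such as an amine or a carboxylic acid in the place of the chloro. Going by these compounds, the benzyloxy group is the same in all four compounds, so what a free hydroxyl or a longer chain at that place would do remains unknown.

Nothing on hand bears on why these steps stay so small.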